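The source may hold more compounds than are shown below. What is called first, only, known or untested is meant among the compounds shown, and "the series" means these compounds.

Compound 1, with the structure `Cc1nc2c(OCc3ccccc3)cccn2c1N`, gives 99% in a functional assay on the whole organism with Rattus norvegicus as the target, at a dose of 40 mg/kg by the intraperitoneal route; a lower number here means less inhibition, a higher number more inhibition at the dose given (going by the name of the read-out); this is the highest of the three numbers measured. Compound 2, with the structure `Nc1cnc2c(OCc3ccccc3)cccn12`, gives 32% in this assay, and compound 3, with the structure `CCCc1nc2c(OCc3ccccc3)cccn2c1N`, gives 31%. The step of a number 67 percentage points lower from compound 1 to compound 2 (beyond the scatter) and the step of a number 68 percentage points lower from compound 1 to compound 3 (beyond the scatter) are both large, while the step of a number 1 percentage points lower from compound 2 to compound 3 (within the scatter) stays within the scatter.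

Compound 4, with the structure `Cc1nc2c(OCc3ccccc3F)cccn2c1N`, differs from compound 1 by one change: fluoro in place of hydrogen on an aromatic carbon. Both measured steps concern the methyl on an aromatic carbon of the shared core and change only that part. Among the measured compounds shown here, none of them touches the six-membered aromatic ring of carbon only, so no measured step bears directly on this change. Since compound 1 already stands near the top of the scale, any movement is expected to be downward and moderate, estimated as a number 11 percentage points lower from compound 1 to compound 4 (beyond the scatter). Compound 4 is expected to give about 88% in this assay, with a range from 55% to 100%.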

Compound 4, a percentage reported as inhibition, in the whole organism at one dose (the size of the read-out at that dose, not a potency): 93%
The estimate for compound 4 lay 5 percentage points below the measured number; the range from low to high includes it.
By their numbers in this assay, from the lowest: compounds 3 and 2 (each within the scatter of the next); then compounds 4 and 1 (each within the scatter of the next).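

The step of a number 6 percentage points lower from compound 1 to compound 4 (within the scatter) in this assay is the first one shown on the six-membered aromatic ring of carbon only, and it shows that fluoro can replace hydrogen at this place, ortho to a large group, without a change beyond the scatter. This contrasts with the methyl on the shared core, where the step of a number 67 percentage points lower from compound 1 to compound 2 (beyond the scatter) and the step of a number 68 percentage points lower from compound 1 to compound 3 (beyond the scatter) are both large, so the high number of compound 1 survives this ring change but not those two changes. No measurement here explains this result.

Only fluoro is shown on this ring, so it remains open whether a chlorine atom, a methoxy group or an amine at the same place would also keep the number high. Readings at a single dose also leave open whether compound 1 and compound 4 would still match at a lower dose.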